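Quinoline core: methoxyphenyl to cyanophenyl swap

The source may report more compounds than this note shows. Statements on the series, on what has been measured and on what is new or still open speak of the compounds shown alone.

Compound 1, `FC(F)(F)c1nc2c(Br)cccc2c(Cl)c1Br` — in an assay for inhibition of ectonucleoside triphosphate diphosphohydrolase 2 (Homo sapiens), read by malachite green, with a stated time of 10 min (on this read-out lower numbers stand for stronger inhibition and higher numbers for weaker inhibition), compound 1 gives > 300000 nM, a limit of the assay.
Compound 2, `COc1ccc(-c2cccc3c(Cl)c(Br)c(C(F)(F)F)nc23)cc1` — in this assay compound 2 gives > 300000 nM, a limit of the assay.

Compound 2 stands at the limit of this assay; it is the limit of > 300000 nM in this assay, at which 2 of the 2 values shown sit. Going by the values given here, the only measured step, a step that the two limits leave unreadable from compound 1 to compound 2, is therefore unreadable in size and in direction, since both ends are limits rather than numbers. Compound 3, `N#Cc1cccc(-c2cccc3c(Cl)c(Br)c(C(F)(F)F)nc23)c1`, differs from compound 2 by a single change: 3-cyanophenyl in place of 4-methoxyphenyl on an aromatic carbon. Among the compounds with values here, no measured step bears on this exchange. The one step that is known, from a bromo to a 4-methoxyphenyl substituent, left the read-out at the limit, and the shared core of compound 1 and compound 2 has not shown inhibition within the range of this assay. The expectation for compound 3 is therefore that the step that the limit leaves unreadable from compound 2 to compound 3 is not resolved beyond the scatter and that the assay most likely again reports only a limit. Compound 3 is estimated at 400000 nM, with a range from 50000 nM to 3000000 nM.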

Compound 3, half-maximal inhibitory concentration: > 300000 nM
Compound 3: no number, only a limit; the forecaster's own chance of this, stated with the estimate: 85%; the middle value lies beyond the limit too.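

Compound 3 gives > 300000 nM in this assay, a limit of the assay and not a number. Going by these compounds alone, no step among compound 1, compound 2 and compound 3 can therefore be read. The compounds shown leave open whether any group on this aromatic carbon of the shared core gives a measurable value in this assay.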